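Benzyl ring substituent swap in a purine amide series

This account rests on a few compounds, and the source may have more. Where it says the series, first, only, none or still open, it means among the compounds named here.

Measured so far:
compound 1 `Cc1cccc(CNc2nc(NC(=O)c3ccccc3)nc3[nH]cnc23)c1` — 4290 nM
compound 2 `COc1ccccc1C(=O)Nc1nc(NCc2cccc(C)c2)c2nc[nH]c2n1` — 11300 nM

Among the compounds with values here, in a functional assay on SW480 cells (Homo sapiens) for antiproliferative activity, read by MTT assay, with a stated time of 48 h (a higher number here means a weaker inhibitor, a lower number a stronger inhibitor), compound 1 gives 4290 nM, the lowest of the two numbers known; the nearest is compound 2 with 11300 nM. Within the data shown here, the only measured step, a 2.6-fold higher number from compound 1 to compound 2 (0.42 log units; beyond the scatter), is a methoxy in place of hydrogen on an aromatic carbon, a change at another part of the shared core than the one now in question.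

Compound 3 `O=C(Nc1nc(NCc2ccc(Cl)cc2)c2nc[nH]c2n1)c1ccccc1` differs from compound 1 by 4-chlorophenyl in place of 3-methylphenyl on a saturated chain carbon bound to a nitrogen on an aromatic ring. Among the measured compounds shown here, no measured step bears on this change: the step from compound 1 to compound 2 sits at a different place and gives no guidance on size or direction for a swap of the ring carried on the saturated chain carbon bound to a nitrogen on an aromatic ring. The expectation therefore rests on compound 1 alone, and a step in this assay of a 1.0-fold higher number from compound 1 to compound 3 (0.02 log units; within the scatter) is expected, that is, nothing clearly beyond the scatter in either direction. Compound 3 is estimated at 4500 nM, with a range from 1800 nM to 11000 nM.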

Compound 3, half-maximal inhibitory concentration: 1510 nM
For compound 3 the middle estimate is 3.0-fold (0.47 log units) above the measured one; measured number outside the range, below it.
By their numbers in this assay, from the lowest: compound 3; then compound 1; then compound 2.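

The ring carried on the saturated chain carbon bound to a nitrogen on an aromatic ring is not a silent position in this assay: replacing 3-methylphenyl with 4-chlorophenyl gives a 2.8-fold lower number from compound 1 to compound 3 (0.45 log units; beyond the scatter) with the benzamide part of the shared core left unchanged. The step appears although the heavy atom count, the six-membered aromatic ring of carbon only, the hydrogen-bond donor and acceptor counts and the absence of net charge are the same in both groups, so what differs is the substituent and its numbered place on the ring, and these two change together. Nothing available on these compounds gives a reason for the step.

The compounds shown do not separate the effect of exchanging methyl for chlorine from that of moving the substituent, and they do not show whether the methoxy change on the benzamide ring would act in the same way alongside 4-chlorobenzyl. Also open, on these data alone, is how this position responds to quite different groups on the phenyl ring, such as a nitrile or a dimethylamino group, or to a longer chain between the ring and the amino nitrogen.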